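Working notes: methyl-to-chloro swap on the fused ring

The source may hold more compounds than are shown below. What is called first, only, known or untested is meant among the compounds shown, and "the series" means these compounds.

Measured compounds:
compound 1 `Cc1nnc(Sc2c(C)oc3ccccc3c2=O)o1`: > 50000 nM
compound 2 `Cc1nnc(SCc2coc3ccc(Cl)cc3c2=O)s1`: 2200 nM
compound 3 `Cc1ccc2oc(CSc3nc4nc(C)cc(C)n4n3)cc(=O)c2c1`: > 25000 nM

All values come from a functional assay on MDA-MB-435S cells (Homo sapiens) for cytotoxicity, read by MTT assay, with a stated time of 72 h; a lower number here means a stronger inhibitor, a higher number a weaker inhibitor. For compound 1 the reported value > 50000 nM is a limit of the assay, not a number; it corresponds to the limit of > 50000 nM in this assay, at which 1 of the 3 values shown sits. Among the compounds with values here, compound 2 gives 2200 nM, the only numeric reading among the three. For compound 3 the value > 25000 nM is again a limit rather than a number, matching (the limit of > 25000 nM in this assay, at which 1 of the 3 values shown sits). Compound 3 therefore stands with the weak end of the set: no potency was resolved for it, and compound 1 is in the same situation, while compound 2 alone shows measurable inhibition.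

Within the data shown here, no two measured compounds differ in a single place, so no measured step size is available to anchor the next change.

Compound 4 `Cc1cc(C)n2nc(SCc3cc(=O)c4cc(Cl)ccc4o3)nc2n1` is not yet measured. Relative to compound 3 the change is chloro in place of methyl on an aromatic carbon. Compound 2 also carries chloro on a fused ring and gives a number, but its core differs from that of compound 3, so its value is not a direct guide. Given that compound 3 sits at a limit, the expected step of an at least 1.6-fold lower number from compound 3 to compound 4 (0.22 log units; that floor lies within the scatter) is a modest gain at most, possibly none beyond the scatter. For compound 4 the estimate is 15000 nM, with a range from 4000 nM to 50000 nM.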

Compound 4, half-maximal inhibitory concentration: > 25000 nM
Compound 4: a limit, no number; the forecaster's own chance of this, stated with the estimate: 45%; middle value at least 1.6-fold (0.22 log units) from the limit.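

In this assay compound 3 gives > 25000 nM, a limit and not a number. Compound 4 gives > 25000 nM, again a limit, so no step can be read between compound 3 and compound 4. The compounds shown leave open whether chloro in place of methyl on an aromatic carbon changes potency in this pair.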